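This account rests on a few compounds, and the source may have more. Where it says the series, first, only, none or still open, it means among the compounds named here.

Values in a functional assay on MGC-803 cells (Homo sapiens) for cytotoxicity, read by MTT assay, with a stated time of 38 h (on this read-out higher numbers stand for weaker inhibition and lower numbers for stronger inhibition), so far:
- compound 1 `COc1cc(OC)c2c(=O)c(OCCCCN3CCCC3)c(-c3cc(OC)c(OC)c(OC)c3)oc2c1` gives 18600 nM
- compound 2 `COc1cc(OC)c2c(=O)c(OCC(=O)N/N=C/c3ccc(C)cc3)c(-c3cc(OC)c(OC)c(OC)c3)oc2c1` gives 3510 nM
- compound 3 `COc1cc(OC)c2c(=O)c(OCCCN3CCCC3)c(-c3cc(OC)c(OC)c(OC)c3)oc2c1` gives 32100 nM

Compound 3 sits at the high end of these numbers, level with compound 1 (a 1.7-fold higher number from compound 1 to compound 3 (0.24 log units; within the scatter)) and apart from compound 2 (a 9.1-fold higher number from compound 2 to compound 3 (0.96 log units; beyond the scatter)). The change to compound 4 `COc1cc(OC)c2c(=O)c(OCC(=O)N/N=C/c3ccccn3)c(-c3cc(OC)c(OC)c(OC)c3)oc2c1` is a group of 11 heavy atoms (7 carbon, 3 nitrogen, 1 oxygen; one six-membered aromatic ring with 1 hetero atom) in place of a group of 7 heavy atoms (6 carbon, 1 nitrogen; one five-membered non-aromatic ring with 1 hetero atom), on a saturated chain carbon bound to an oxygen on an aromatic ring at the same place. The nearest measured exchanges are those involving compound 2 (a 5.3-fold lower number from compound 1 to compound 2 (0.72 log units; beyond the scatter)) and (a 9.1-fold higher number from compound 2 to compound 3 (0.96 log units; beyond the scatter)), both modest and beyond the scatter, with the lower number on the side carrying the six-membered aromatic ring. A modest drop is therefore expected in this assay (a 6.4-fold lower number from compound 3 to compound 4 (0.81 log units; beyond the scatter)). Compound 4 is estimated at 5000 nM (expected range 1500 nM to 16000 nM).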

Compound 4, half-maximal inhibitory concentration: 15300 nM
Estimate against measurement, compound 4: 3.1-fold (0.49 log units) below; measured number inside the range.
By their numbers in this assay, from the lowest: compound 2; then compounds 4, 1 and 3 (each within the scatter of the next, the first and the last beyond it).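

In this assay pyridin-2-yl in place of 4-methylphenyl on a carbon with a double bond to nitrogen is a modest loss (a 4.4-fold higher number from compound 2 to compound 4 (0.64 log units; beyond the scatter)), so the chain shared by compound 2 and compound 4 does not alone set the low number of compound 2. That chain in compound 4 keeps only a modest edge over the pyrrolidine chain of compound 3 (a 2.1-fold lower number from compound 3 to compound 4 (0.32 log units; beyond the scatter)) and stands level with compound 1 (a 1.2-fold lower number from compound 1 to compound 4 (0.08 log units; within the scatter)).

Nothing at hand explains the difference between the two rings. Open, on these data alone, is how phenyl or 4-methoxyphenyl on that carbon would read.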